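A few compounds are considered here, and "the series" means these few. Any claim that something is new, unique, unknown or untested is made for them only; others in the source may bear on it.

Compound 1, `COc1cncc(-c2cccc(-c3cn4cccc(C(N)=O)c4n3)c2)c1`: in a physicochemical assay for solubility, in phosphate buffer, with a stated time of 24 h, at pH 7.4 (a higher number here means a more soluble compound, a lower number a less soluble compound), compound 1 gives < 1000 nM, which is a limit of the assay, not a number.
Compound 2, `NC(=O)c1cccn2cc(-c3cccc(-c4cncc(OCC(F)F)c4)c3)nc12`: in this assay compound 2 gives < 1000 nM, again a limit.
Compound 3, `NC(=O)c1cccn2cc(-c3cccc(-c4cncc(OC[C@H]5CCCO5)c4)c3)nc12`: in this assay compound 3 gives 5300 nM.

Compound 3 thus holds the only number shown; the two other values sit at the limit of < 1000 nM in this assay, at which 2 of the 3 values shown sit. Compound 4, `NC(=O)c1cccn2cc(-c3cccc(-c4cncc(OCCF)c4)c3)nc12`, differs from compound 3 by fluoromethyl in place of oxolan-2-yl on a saturated chain carbon bound to an oxygen on an aromatic ring. Within the data shown here, the steps that bear on this run the other way: an at least 5.3-fold higher number from compound 1 to compound 3 (0.72 log units; beyond the scatter) and an at least 5.3-fold higher number from compound 2 to compound 3 (0.72 log units; beyond the scatter), while a step that the two limits leave unreadable from compound 1 to compound 2. Returning to a small group is therefore expected to reverse that gain, and the step expected is a 5.9-fold lower number from compound 3 to compound 4 (0.77 log units; beyond the scatter). Compound 4 is estimated at 900 nM, with a range for compound 4 from 300 nM to 2700 nM, and a real chance that only a limit is reported.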

Compound 4, solubility: 16000 nM
For compound 4 the middle estimate is 18-fold (1.25 log units) below the measured one; measured number outside the range, above it.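

At this place, on a saturated chain carbon bound to an oxygen on an aromatic ring, the oxolan-2-yl ring is not needed for a high number in this assay: fluoromethyl in its place gives a 3.0-fold higher number from compound 3 to compound 4 (0.48 log units; beyond the scatter). The change is also sharply dependent on the end group, with hydrogen in place of fluoro giving an at least 16-fold higher number from compound 2 to compound 4 (1.20 log units; beyond the scatter), and fluoromethyl in place of hydrogen giving an at least 16-fold higher number from compound 1 to compound 4 (1.20 log units; beyond the scatter). Both of these steps start from a limit of the assay, not a number: the limit of < 1000 nM in this assay, at which 2 of the 4 values shown sit.

The compounds shown leave open whether a longer chain such as 3-fluoropropyl, or an amine on this carbon, would hold such a number. They also leave open whether the mirror-image form of the oxolan-2-yl group would match compound 3.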